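The compounds below may be only part of what the source reports. "The series", "measured", "known", "first", "only" and "open" are said of these compounds alone.

Working notes on the series. In a functional assay on MCF7 cells (Homo sapiens) for cytotoxicity, read by MTT assay, with a stated time of 48 h (a higher number here means a weaker inhibitor, a lower number a stronger inhibitor), compound 1 `CNC(=O)CSc1nc2ccc(NC(=O)c3ccccc3OC)cc2s1` gives 23400 nM and compound 2 `COc1ccc(CNC(=O)CSc2nc3ccc(NC(=O)c4ccccc4)cc3s2)cc1` gives 21200 nM; the two values lie within the scatter of each other, so compound 1 stands at the same level as compound 2 and no order between them can be read. Compound 3 `O=C(CSc1nc2ccc(NC(=O)c3ccc([N+](=O)[O-])cc3)cc2s1)NCc1ccccc1` reaches only the limit > 100000 nM in this assay, which is a limit of the measurement and not a number (the limit of > 100000 nM in this assay, at which 1 of the 3 values shown sits). Compound 4 `CNC(=O)CSc1nc2ccc(NC(C)=O)cc2s1` remains to be measured in this assay; it differs from compound 1 by methyl in place of 2-methoxyphenyl on a carbonyl carbon. With no measured step of this kind in the series, a weakening beyond the scatter is expected, a 1.9-fold higher number from compound 1 to compound 4 (0.28 log units; within the scatter). Compound 4 is thus estimated at 45000 nM, within 15000 nM to 100000 nM.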

Compound 4, half-maximal inhibitory concentration: > 100000 nM
Compound 4 ended at the assay's limit; the forecaster's own chance of this, stated with the estimate: 35%; middle value at least 2.2-fold (0.34 log units) from the limit.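

In this assay, methyl in place of 2-methoxyphenyl on a carbonyl carbon gives an at least 4.2-fold higher number from compound 1 to compound 4 (0.63 log units; beyond the scatter). For the compounds shown here, this is the first single-place step, and it shows that this position is not indifferent: losing the aromatic ring here costs activity beyond the scatter. As far as these compounds go, the value of compound 4 is a limit and not a number, so the full size of the step stays unknown: the limit of > 100000 nM in this assay, at which 2 of the 4 values shown sit.

Open, from the compounds shown here alone, is whether a cyclohexyl or a pyridine ring in this place would hold the level of compound 1. Also open, going by these compounds, is what the methoxy group of 2-methoxyphenyl contributes on its own.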